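A few compounds are considered here, and "the series" means these few. Any claim that something is new, unique, unknown or untested is made for them only; others in the source may bear on it.

Working notes on the series. In a functional assay on HL-60 cells (Homo sapiens), with a stated time of 2 days (on this read-out lower numbers stand for stronger inhibition and higher numbers for weaker inhibition), compound 1 `O=C(Nc1ccc(Cl)c(Cl)c1)c1nc[nH]c1C(=O)NCc1ccc(Cl)cc1` gives 16200 nM. Compound 2 `Cc1ccc(CNC(=O)c2[nH]cnc2C(=O)Nc2ccc(Cl)c(Cl)c2)cc1` gives 21400 nM in this assay, a step of a 1.3-fold higher number from compound 1 to compound 2 (0.12 log units; within the scatter). Compound 3 `COC(=O)[C@@H](C)NC(=O)c1[nH]cnc1C(=O)Nc1ccc(Cl)c(Cl)c1` reaches only a limit, > 62500 nM, in this assay, so compound 3 stands without a number of its own. The steps that lead to it, an at least 3.8-fold higher number from compound 1 to compound 3 (0.58 log units; beyond the scatter) and an at least 2.9-fold higher number from compound 2 to compound 3 (0.46 log units; beyond the scatter), both run into (the limit of > 62500 nM in this assay, at which 1 of the 3 values shown sits). Compound 4 `COC(=O)[C@H](NC(=O)c1[nH]cnc1C(=O)Nc1ccc(Cl)c(Cl)c1)C(C)C` differs from compound 3 by isopropyl in place of methyl on a saturated chain carbon bound to an amide-type nitrogen and a carbonyl carbon. Among the compounds with values here, no measured step touches this chain; the two steps ending at compound 3 exchange the whole group on the amide nitrogen and do not speak to the ester side chain. The expected step from compound 3 is therefore none beyond the scatter, a step that the limit leaves unreadable from compound 3 to compound 4. Compound 4 is estimated near 80000 nM, within 30000 nM to 250000 nM, most likely reported again only as a limit.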

Compound 4, half-maximal inhibitory concentration: 8500 nM
Beside the measured number, compound 4's estimate is 9.4-fold (0.97 log units) above it; measured number outside the range, below it.
By their numbers in this assay, from the lowest: compounds 4, 1 and 2 (each within the scatter of the next, the first and the last beyond it). At a limit, above all of these: compound 3.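

Isopropyl in place of methyl on a saturated chain carbon bound to an amide-type nitrogen and a carbonyl carbon gives an at least 7.3-fold lower number from compound 3 to compound 4 (0.86 log units; beyond the scatter) in this assay, so this side chain does bear on the read-out. On these data alone, the full size of that step stays unknown, as compound 3 gives only a limit: the limit of > 62500 nM in this assay, at which 1 of the 4 values shown sits. The ester-bearing group can also match or pass the benzyl groups: 1-(methoxycarbonyl)-2-methylpropyl gives a 2.5-fold lower number from compound 2 to compound 4 (0.40 log units; beyond the scatter) and a 1.9-fold lower number from compound 1 to compound 4 (0.28 log units; within the scatter).

As far as these compounds go, whether tert-butyl or isobutyl at this carbon would carry the trend further remains open. So does the effect of a carboxylic acid in place of the methoxycarbonyl group.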